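The source may hold more compounds than are shown below. What is called first, only, known or untested is meant among the compounds shown, and "the series" means these compounds.

The series rests on a shared core, carried by compound 1 `Cc1nc2c([nH]1)C(=O)/C(=N/c1ccc(Cl)cc1Cl)C(Cl)=C2O` and compound 2 `Cc1nc2c([nH]1)C(=O)/C(=N/c1ccc(F)cc1)C(Cl)=C2O`. In a functional assay (Rattus norvegicus) for antiproliferative activity (a lower number here means a stronger inhibitor, a higher number a weaker inhibitor), compound 1 gives 800 nM, and in this assay compound 2 gives 3000 nM. Within the data shown here, compound 2 thus stands at the higher of the two numbers known so far, and its distance from compound 1, the only neighbour, lies beyond the usual scatter of this measurement. Compound 3 `Cc1nc2c([nH]1)C(=O)/C(=N/c1ccc(C(F)(F)F)cc1)C(Cl)=C2O` has not yet been measured. It differs from compound 2 in one place: trifluoromethyl in place of fluoro on an aromatic carbon. Among the measured compounds shown here, no pair of measured compounds covers this change, so the two values at hand give no direct guide to its size or direction. The step that the estimate means is a 1.5-fold lower number from compound 2 to compound 3 (0.18 log units; within the scatter), expected to be modest and to lean toward a lower number, though a change of no size beyond the scatter is also possible. For compound 3 in this assay a value of 2000 nM is estimated, expected to fall between 600 nM and 6000 nM.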

Compound 3, half-maximal inhibitory concentration: 600 nM
For compound 3 the middle estimate is 3.3-fold (0.52 log units) above the measured one; the range from low to high includes it.
By their numbers in this assay, from the lowest: compounds 3 and 1 (each within the scatter of the next); then compound 2.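

In this assay, among these compounds, this is the first step across a single change: trifluoromethyl in place of fluoro, on an aromatic carbon para to a large group, gives a 5.0-fold lower number from compound 2 to compound 3 (0.70 log units; beyond the scatter), beyond the scatter. Compound 1 and compound 2 differ in more than one place, so their values could not isolate the effect of any one group, whereas this pair shows that the number responds to the group held at this position. Here the group of 4 heavy atoms goes with the lower number than the group of 1 heavy atom, and no measurement at hand explains the step.

The compounds shown leave open whether this trend extends to other groups at this position, such as a nitrile, a methoxy group, an amine or a carboxylic acid, since one pair sets no order among substituents. They also leave open whether the same exchange would give a step of similar size with the chloro groups of compound 1 on the aromatic ring.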